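The compounds below may be only part of what the source reports. "The series", "measured", "known", "first", "only" and "open" are said of these compounds alone.

Measured in a functional assay on the whole organism (strain Wistar) for inhibition, with Rattus norvegicus as the target, with stated times of 30 min and 3 h, at a dose of 20 mg/kg by the oral route; on this read-out higher numbers stand for more inhibition at the one dose given (going by the name of the read-out) and lower numbers for less inhibition:
compound 1 `Cc1ccc(C(=O)CCc2nnc(-c3ccc(Cl)cc3)o2)cc1` gives 81.5%
compound 2 `COc1ccc(-c2nnc(CCC(=O)c3ccc(C)cc3)o2)cc1` gives 89.5%
compound 3 `Cc1ccc(C(=O)CCc2nnc(Cc3ccccc3)o2)cc1` gives 51.9%

Compound 3 holds the lowest of the three numbers. The two steps leading down to it are a number 29.6 percentage points lower from compound 1 to compound 3 (beyond the scatter) and a number 37.6 percentage points lower from compound 2 to compound 3 (beyond the scatter); both of those changes exchange an aryl group on the aromatic carbon for a benzyl. Between compound 1 and compound 2 the step is a number 8 percentage points higher from compound 1 to compound 2 (within the scatter), so the two aryl variants are not separated from each other.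

Compound 4 `Cc1ccc(C(=O)CCc2nnc(COc3ccccc3)o2)cc1` differs from compound 3 in one place: phenoxy in place of phenyl on a saturated chain carbon bound to an aromatic carbon. For the measured compounds named here, no measured step covers an exchange of this kind. The two steps that lead to compound 3 both trade an aryl for a benzyl and both gave drops beyond the scatter, but they say nothing about going from benzyl to phenoxymethyl while the ring itself is kept. Going by the values given here, the change is small by its count of heavy atoms, and there is no precedent for its effect. The expectation for compound 4 in this assay is therefore a step of a number 3.1 percentage points higher from compound 3 to compound 4 (within the scatter), that is, no movement beyond the scatter. Compound 4 is estimated at 55% with a range from 35% to 75%.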

Compound 4, a percentage reported as inhibition, in the whole organism at one dose (the size of the read-out at that dose, not a potency): 42%
Beside the measured number, compound 4's estimate is 13 percentage points above it; the measured number falls inside the stated range.
By their numbers in this assay, from the lowest: compounds 4 and 3 (each within the scatter of the next); then compounds 1 and 2 (each within the scatter of the next).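

In this assay, for the compounds shown here, the exchange of phenyl for phenoxy on a saturated chain carbon bound to an aromatic carbon gives a number 9.9 percentage points lower from compound 3 to compound 4 (within the scatter), the first reading of a change that keeps the ring and alters only the link to it, and benzyl and phenoxymethyl are not separated by it. Set against the two aryl compounds, phenoxymethyl gives a number 47.5 percentage points lower from compound 2 to compound 4 (beyond the scatter) and a number 39.5 percentage points lower from compound 1 to compound 4 (beyond the scatter), so among the four compounds shown, a drop beyond the scatter on leaving 4-methoxyphenyl or 4-chlorophenyl is now seen with a second group that has its ring on a saturated chain carbon, with no compound here going against it. No available evidence bears on what lies behind these numbers.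

The compounds shown leave open whether an unsubstituted phenyl on the aromatic carbon would stand with the two substituted aryl compounds or with benzyl and phenoxymethyl. Also open, going by these compounds, is how a chloro or methoxy group on the ring of phenoxymethyl, or a longer chain in its place, would read in this assay.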